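The compounds below may be only part of what the source reports. "The series", "measured", "known", "first", "only" and "open" are said of these compounds alone.

Compound 2 `CCCCC(=O)NCCCO[C@@H]1[C@@H](C)N(C)C[C@H](C)C[C@@](C)(O)[C@H](O[C@@H]2O[C@H](C)C[C@H](N(C)C)[C@H]2O)[C@@H](C)[C@H](O[C@H]2C[C@@](C)(OC)[C@@H](O)[C@H](C)O2)[C@@H](C)C(=O)O[C@H](CC)[C@@]1(C)O` stands at the top of the three numbers in a physicochemical assay for lipophilicity, read by HPLC, measured as chromatographic lipophilicity, at pH 7.4 (a higher number here means a more lipophilic compound, a lower number a more polar compound), where compound 2 gives 3.74. For the measured compounds named here, its nearest neighbour is compound 1 `CC[C@H]1OC(=O)[C@H](C)[C@@H](O[C@H]2C[C@@](C)(OC)[C@@H](O)[C@H](C)O2)[C@H](C)[C@@H](O[C@@H]2O[C@H](C)C[C@H](N(C)C)[C@H]2O)[C@](C)(O)C[C@@H](C)CN(C)[C@H](C)[C@@H](OCCCNC(=O)C2CCC2)[C@]1(C)O`, which in this assay gives 3.5, and the single measured step between the two, a number 0.24 log units higher from compound 1 to compound 2 (within the scatter), falls within the scatter. Going by the values given here, the furthest is compound 3 `CCCCC(=O)NCCCN(C)[C@H]1C[C@@H](C)O[C@@H](O[C@@H]2[C@@H](C)[C@H](O[C@H]3C[C@@](C)(OC)[C@@H](O)[C@H](C)O3)[C@@H](C)C(=O)O[C@H](CC)[C@@](C)(O)[C@H](O)[C@@H](C)N(C)C[C@H](C)C[C@@]2(C)O)[C@@H]1O`, which gives 3.08, beyond the scatter from compound 2; no single step links compound 3 to the others, so only the two values themselves can be compared.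

Compound 4 `CC[C@H]1OC(=O)[C@H](C)[C@@H](O[C@H]2C[C@@](C)(OC)[C@@H](O)[C@H](C)O2)[C@H](C)[C@@H](O[C@@H]2O[C@H](C)C[C@H](N(C)C)[C@H]2O)[C@](C)(O)C[C@@H](C)CN(C)[C@H](C)[C@@H](OCCCNC(=O)c2c(C)nn(C)c2Cl)[C@]1(C)O` is not yet measured. It differs from compound 2 as follows: 5-chloro-1,3-dimethyl-1H-pyrazol-4-yl in place of butyl on a carbonyl carbon. Among the compounds with values here, the only measured step touching the same carbonyl carbon is a number 0.24 log units higher from compound 1 to compound 2 (within the scatter), a chain for a ring of the same carbon count, and it stayed within the scatter. Within the data shown here, no measured step covers a five-membered aromatic ring with two hetero atoms and a chlorine entering at this place, so the direction is not anchored by the data. On that basis the author expects compound 4 to land close to compound 2, with any step a number 0.24 log units lower from compound 2 to compound 4 (within the scatter) as likely within the scatter as beyond it. The estimate for compound 4 is 3.5, within a range from 3 to 4.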

Compound 4, distribution coefficient: 3.01
Estimate against measurement, compound 4: 0.49 log units above; the range from low to high includes it.
By their numbers in this assay, from the lowest: compounds 4 and 3 (each within the scatter of the next); then compounds 1 and 2 (each within the scatter of the next).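

Compound 4 shows that this carbonyl carbon can move the reading in this assay beyond the scatter. For the compounds shown here, until now, the only exchange measured here, a chain for a ring of the same carbon count, had stayed within it. With 5-chloro-1,3-dimethyl-1H-pyrazol-4-yl entering, the result is a number 0.73 log units lower from compound 2 to compound 4 (beyond the scatter) against butyl and a number 0.49 log units lower from compound 1 to compound 4 (beyond the scatter) against cyclobutyl, so the lower reading holds against both the open chain and the saturated ring, even though the entering group counts more heavy atoms than either and brings hydrogen-bond acceptors that neither has. Nothing given here bears on why the number falls with this group.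

The compounds shown leave open which part of the entering group goes with the lower number, as the aromatic ring, its two nitrogens, the chlorine and the two methyl groups all arrive together in one change. A phenyl ring or 1,3-dimethyl-1H-pyrazol-4-yl without the chlorine on this carbonyl carbon would begin to separate these parts, and a longer chain in place of butyl would show how far the reading follows chain length at this place.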